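The compounds below may be only part of what the source reports. "The series", "measured", "known", "first", "only" and "open" are said of these compounds alone.

Measured so far:
compound 1 `Cc1ncc(CN[C@@H]2C[C@@H]3C[C@H]([C@H]2C)C3(C)C)[nH]1` — 202000 nM
compound 2 `CCc1ncc(CN[C@@H]2C[C@@H]3C[C@H]([C@H]2C)C3(C)C)[nH]1` — 137000 nM
compound 3 `CCc1nc(C)c(CN[C@@H]2C[C@@H]3C[C@H]([C@H]2C)C3(C)C)[nH]1` — 136000 nM

All three numbers come from an ADME assay on MDCK cells (Canis lupus familiaris) for cytotoxicity, read by MTT assay, with a stated time of 48 h; a higher number here means that more compound is tolerated, a lower number that less compound is tolerated. The step of a 1.5-fold lower number from compound 1 to compound 2 (0.17 log units; within the scatter) is made by methyl in place of hydrogen on a saturated chain carbon bound to an aromatic carbon. The further step a 1.0-fold lower number from compound 2 to compound 3 (0.00 log units; within the scatter) changes nothing that the scatter would not cover, so the three values sit together and no order among them can be read.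

Compound 4 `Cc1nc(C(C)C)[nH]c1CN[C@@H]1C[C@@H]2C[C@H]([C@H]1C)C2(C)C` is not yet measured. It differs from compound 3 by methyl in place of hydrogen on a saturated chain carbon bound to an aromatic carbon and a saturated chain carbon. This is the same kind of change as that from compound 1 to compound 2, not the same: there the place was a saturated chain carbon bound to an aromatic carbon, here a saturated chain carbon bound to an aromatic carbon and a saturated chain carbon. The difference between the two cores, compound 1 against compound 3, is not broken down here.

For this assay the expected step is a 1.2-fold lower number from compound 3 to compound 4 (0.09 log units; within the scatter), because the earlier step of a 1.5-fold lower number from compound 1 to compound 2 (0.17 log units; within the scatter) of the same kind stayed within the scatter and gives no ground for a larger move. Compound 4 is therefore estimated at 110000 nM, with 55000 nM to 220000 nM as the expected range.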

Compound 4, half-maximal cytotoxic concentration: 73100 nM
Estimate against measurement, compound 4: 1.5-fold (0.18 log units) above; the measured number falls inside the stated range.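

In this assay, methyl in place of hydrogen on a saturated chain carbon bound to an aromatic carbon and a saturated chain carbon, which reads as ethyl to isopropyl, gives a 1.9-fold lower number from compound 3 to compound 4 (0.27 log units; within the scatter). Set beside the same kind of change on the other core, the two steps cannot be told apart: the same change on two cores in this assay, a 1.5-fold lower number (0.17 log units; within the scatter) from compound 1 to compound 2 and a 1.9-fold lower number (0.27 log units; within the scatter) from compound 3 to compound 4, 1.3-fold (0.10 log units) apart, within the scatter of two such steps. Across these four compounds the change therefore carries from one core to the other without a detectable difference, but both steps lie within the scatter, so this does not show a real effect of the change on either core, nor that its size is constant across the series.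

The groups shown at this place are only methyl, ethyl and isopropyl, so whether a longer chain, a cyclopropyl ring, a carboxylic acid or an amine there would give a step beyond the scatter stays open. Going by these compounds, whether the change carries over to a core beyond these two also stays open.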